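A few compounds are considered here, and "the series" means these few. Any claim that something is new, unique, unknown or untested is made for them only; others in the source may bear on it.

Working notes on the series, read in an ADME assay (liver) for metabolic stability, with Liver microsome (Homo sapiens) as the target, using microsomes; on this read-out lower numbers stand for slow clearance and higher numbers for fast clearance. For the measured compounds named here, compound 3 `Cc1cc2c(Oc3cnc(C(=O)N(C)C)cn3)cc(C(=O)Nc3cnccn3)cc2o1` gives 15 mL/min/kg, the only actual number among the three values so far. Compound 1 `Cc1cnc(NC(=O)c2cc(Oc3cnc(C(=O)N(C)C)cn3)c3cc(C)oc3c2)cn1` is reported only as a limit, < 8.5 mL/min/kg. Compound 2 `Cc1ccc(NC(=O)c2cc(Oc3cnc(C(=O)N(C)C)cn3)c3cc(C)oc3c2)nc1` is likewise reported only as a limit, < 10.6 mL/min/kg.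

Compound 4 `COc1cnc(NC(=O)c2cc(Oc3cnc(C(=O)N(C)C)cn3)c3cc(C)oc3c2)cn1` adds one change to compound 3: methoxy in place of hydrogen on an aromatic carbon. This is methoxy in place of hydrogen on an aromatic carbon, with pyrazin-2-yl becoming 5-methoxypyrazin-2-yl.

The closest evidence is the step of an at least 1.7-fold higher number from compound 1 to compound 3 (0.24 log units; that floor lies within the scatter), which is hydrogen in place of methyl on the same kind of ring. Read backwards, it points toward a lower number when the hydrogen is replaced, but methoxy itself has not been measured here. The step of an at least 1.4-fold higher number from compound 2 to compound 3 (0.15 log units; that floor lies within the scatter) also changes the ring, and the step that the two limits leave unreadable from compound 1 to compound 2 cannot be read. A modest fall that stays within the scatter is therefore expected, and the estimated step is a 1.5-fold lower number from compound 3 to compound 4 (0.18 log units; within the scatter). For compound 4 the estimated value is 10 mL/min/kg, with an expected range from 6 mL/min/kg to 20 mL/min/kg.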

Compound 4, clearance: < 8 mL/min/kg
Compound 4: no number, only a limit; the forecaster's own chance of this, stated with the estimate: 45%; middle value at least 1.2-fold (0.09 log units) away from the limit.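

In this assay, the change from pyrazin-2-yl to 5-methoxypyrazin-2-yl gives an at least 1.8-fold lower number from compound 3 to compound 4 (0.27 log units; that floor lies within the scatter), so methoxy at this aromatic carbon, para to a large group, now has a direct reading, though only as a floor. Compound 4 is reported as a limit and not as a number: the limit of < 8 mL/min/kg in this assay, at which 1 of the 4 values shown sits.
The steps joining compound 4 to compound 1 and to compound 2 link two limits and cannot be read.

As far as these compounds go, how far the true values of compound 1, compound 2 and compound 4 lie from their limits stays open, so methyl and methoxy cannot be ordered at this carbon. Also open, from the compounds shown here alone, is whether an amine, a hydroxyl or a longer chain such as ethoxy at the same carbon would give a number or another limit.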